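Replacing the second quinoline with a tetrazolone-bearing chain

The source may hold more compounds than are shown below. What is called first, only, known or untested is meant among the compounds shown, and "the series" means these compounds.

Measured compounds in a functional assay on NCI-H460 cells (Homo sapiens) for antiproliferative activity, read by sulforhodamine B assay, with a stated time of 72 h; on this read-out higher numbers stand for weaker inhibition and lower numbers for stronger inhibition:
- compound 1 `CN(CCNCc1cn(-c2ccccc2)nn1)CCNc1ccnc2cc(Cl)ccc12`: 25000 nM
- compound 2 `CN(CCNCc1cn(CCCO)nn1)CCNc1ccnc2cc(Cl)ccc12`: > 200000 nM, a limit of the assay the limit of > 200000 nM in this assay, at which 1 of the 3 values shown sits.
- compound 3 `CN(CCNCc1cn(-c2ccnc3cc(Cl)ccc23)nn1)CCNc1ccnc2cc(Cl)ccc12`: 16000 nM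

Compound 3 gives the lowest number shown, but the step of a 1.6-fold lower number from compound 1 to compound 3 (0.19 log units; within the scatter) is within the scatter. The new compound 4 `CN(CCNCc1cn(CCCn2nn[nH]c2=O)nn1)CCNc1ccnc2cc(Cl)ccc12` differs from compound 3 by a group of 9 heavy atoms (4 carbon, 4 nitrogen, 1 oxygen; one five-membered aromatic ring with 4 hetero atoms) in place of a group of 11 heavy atoms (9 carbon, 1 nitrogen, 1 chlorine; one six-membered aromatic ring of carbon only, one six-membered aromatic ring with 1 hetero atom), on an aromatic nitrogen. Among the measured compounds shown here, two measured steps bear on this: an at least 8.0-fold higher number from compound 1 to compound 2 (0.90 log units; beyond the scatter) and an at least 12-fold lower number from compound 2 to compound 3 (1.09 log units; beyond the scatter), both showing that a group other than a six-membered aromatic ring on that nitrogen goes with a markedly higher number. The entering group of compound 4 is likewise not such a ring, so a step of this kind is expected, a 9.4-fold higher number from compound 3 to compound 4 (0.97 log units; beyond the scatter). Compound 4 is therefore estimated at 150000 nM, with a range from 40000 nM to 400000 nM.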

Compound 4, half-maximal inhibitory concentration: > 200000 nM
Compound 4: only a limit was reported; the forecaster's own chance of this, stated with the estimate: 50%; middle value at least 1.3-fold (0.12 log units) away from the limit.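

In this assay the five-membered aromatic ring with 4 hetero atoms, carried on its chain, brings an at least 12-fold higher number from compound 3 to compound 4 (1.09 log units; beyond the scatter) and an at least 8.0-fold higher number from compound 1 to compound 4 (0.90 log units; beyond the scatter). So compound 4 joins compound 2 as a second compound without a six-membered aromatic ring on that nitrogen, and both stand at a limit rather than a number: the limit of > 200000 nM in this assay, at which 2 of the 4 values shown sit. The step between compound 2 and compound 4 cannot be read, so these two groups cannot be ranked. From the compounds shown here alone, it remains open whether an amine or a carboxylic acid at the end of the chain would stay at that limit. Going by these compounds, a five-membered aromatic ring set directly on the nitrogen is equally open.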